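The source may hold more compounds than are shown below. What is called first, only, known or untested is meant among the compounds shown, and "the series" means these compounds.

Compound 2, `COCC(CCC/C=C(\c1ccccc1)c1cccnc1)C(=O)O`, is measured in an assay (Equus caballus) for inhibition of Thromboxane-A synthase (Homo sapiens), using microsomes (on this read-out higher numbers stand for weaker inhibition and lower numbers for stronger inhibition), where compound 2 gives 41 nM. Its two neighbours carry the same core with a different group, or none, on the chain carbon next to the carbonyl: compound 1, `CSC(CCC/C=C(\c1ccccc1)c1cccnc1)C(=O)O`, gives 30 nM, and compound 3, `O=C(O)CCC/C=C(\c1ccccc1)c1cccnc1`, gives 30 nM. The numbers of all three sit together; the step of a 1.4-fold higher number from compound 1 to compound 2 (0.14 log units; within the scatter) and the step of a 1.4-fold lower number from compound 2 to compound 3 (0.14 log units; within the scatter) both fall inside the scatter, and so does no change at the digits printed from compound 1 to compound 3 (within the scatter).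

Compound 4, `O=C(O)C(CCC/C=C(\c1ccccc1)c1cccnc1)C1(O)CCCC1`, carries 1-hydroxycyclopentyl in place of methoxymethyl on a saturated chain carbon bound to a carbonyl carbon and a saturated chain carbon. The two steps that bear on this change are those at the same chain carbon, a 1.4-fold higher number from compound 1 to compound 2 (0.14 log units; within the scatter) and a 1.4-fold lower number from compound 2 to compound 3 (0.14 log units; within the scatter), which show that swapping or dropping the group there left this assay unmoved. The incoming 1-hydroxycyclopentyl is larger, brings a ring and a hydrogen-bond donor, and nothing measured resembles it, so the expectation rests on a widened range. For compound 4 the step from compound 2 is expected to be a 1.2-fold lower number from compound 2 to compound 4 (0.07 log units; within the scatter), nothing beyond the scatter. The estimate for compound 4 in this assay is 35 nM, between 12 nM and 110 nM.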

Compound 4, half-maximal inhibitory concentration: 65 nM
For compound 4 the middle estimate is 1.9-fold (0.27 log units) below the measured one; the measured number falls inside the stated range.
By their numbers in this assay, from the lowest: compounds 1, 3, 2 and 4 (each within the scatter of the next, the first and the last beyond it).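

In this assay, within the data shown here, the 1-hydroxycyclopentyl group, with its five-membered ring and hydrogen-bond donor, is the first group at this saturated chain carbon to give a step beyond the scatter, but only against methylsulfanyl, in a 2.2-fold higher number from compound 1 to compound 4 (0.34 log units; beyond the scatter), and that step is modest. Against methoxymethyl the same group stays within the scatter, in a 1.6-fold higher number from compound 2 to compound 4 (0.20 log units; within the scatter), so the larger group with a ring does not clearly separate from every smaller group at this carbon. Nothing at hand explains the modest step from the methylsulfanyl compound.

As far as these compounds go, whether an amine, a phenyl ring or a longer chain on this carbon would move the number further remains open. So does whether plain cyclopentyl, without the hydroxyl, would read like compound 4.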